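An Ethyl Group on the Ring Nitrogen of Compound 1

The source may report more compounds than this note shows. Statements on the series, on what has been measured and on what is new or still open speak of the compounds shown alone.

Two compounds have been characterised in an assay on HEK293 cells for displacement of a labelled ligand from 5-hydroxytryptamine receptor 4 (Homo sapiens), read by scintillation counting; a lower number here means a stronger inhibitor, a higher number a weaker inhibitor. Within the data shown here, compound 1 `COc1cc(N)c(Cl)cc1C(=O)NC1CCNCC1` gives 1580 nM in this assay, the lower of the two numbers measured so far. Compound 2 `COc1ccc2[nH]cc(C(=O)NCC3CCNCC3)c2c1` gives 3980 nM in this assay, a number higher than that of compound 1 by a margin that exceeds the usual scatter. Among the measured compounds shown here, no pair of measured compounds differs in a single place, so no measured step is available to guide an expectation.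

Compound 3 `CCN1CCC(NC(=O)c2cc(Cl)c(N)cc2OC)CC1` is the compound awaiting measurement. It differs from compound 1 by ethyl in place of hydrogen on an amine nitrogen in a ring. For the measured compounds named here, with no measured step of this kind on hand, the expectation rests on the single change made to compound 1. The expected step, a 2.3-fold lower number from compound 1 to compound 3 (0.35 log units; beyond the scatter), is modest and toward a lower number, though a result within the scatter would not be surprising. Compound 3 is accordingly estimated at 700 nM in this assay, with a range from 250 nM to 2500 nM.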

Compound 3, inhibition constant: 1000 nM
Compound 3: middle estimate off by 1.4-fold (0.15 log units), on the low side; measured number inside the range.
By their numbers in this assay, from the lowest: compounds 3 and 1 (each within the scatter of the next); then compound 2.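

Among these compounds, this is the first step measured at the ring nitrogen, and ethyl in place of hydrogen on this amine nitrogen gives a 1.6-fold lower number from compound 1 to compound 3 (0.20 log units; within the scatter) in this assay for the two compounds. The earlier compounds shown here offered no pair differing in a single place, so they said nothing about this nitrogen; the step now shows that it can carry ethyl, with its 2 heavy atoms, while the number stays within the scatter of that of compound 1. No other measurement at hand bears on this result.

The compounds shown leave open whether other groups on this nitrogen, such as methyl, a longer chain such as butyl, benzyl, or an ethyl chain ending in an amine or a carboxylic acid, would also stay within the scatter of compound 1 or would move the number beyond it. Among the compounds shown here, they also leave open whether ethyl on the ring nitrogen of compound 2 would give a step of similar size, since the only step available comes from the core of compound 1.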